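This account rests on a few compounds, and the source may have more. Where it says the series, first, only, none or still open, it means among the compounds named here.

Measured so far:
Compound 1 `Cc1cccc(-c2cnc(N)nc2-c2ccccc2)c1` gives > 80% in an assay on CHO cells for displacement of a labelled ligand from adenosine receptor A1 (Homo sapiens), read by scintillation counting, with a stated time of 1 h, tested at 1 uM (on this read-out higher numbers stand for more inhibition at the one concentration tested (going by the name of the read-out) and lower numbers for less inhibition), a limit of the assay.
Compound 2 `Nc1ncc(-c2cccc(Cl)c2)c(-c2ccccc2)n1` gives > 80% in this assay, again a limit.
Compound 3 `COc1cccc(-c2cnc(N)nc2-c2ccccc2)c1` gives > 80% in this assay, again a limit.

Compound 2 therefore stands only at a limit of this assay, not at a number. All three values sit at the same limit (the limit of > 80% in this assay, at which 3 of the 3 values shown sit), so the steps a step that the two limits leave unreadable from compound 1 to compound 2, a step that the two limits leave unreadable from compound 1 to compound 3 and a step that the two limits leave unreadable from compound 2 to compound 3 cannot be sized; each exchange of methyl, chloro and methoxy on that aromatic carbon left the read-out at the limit.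

Compound 4 `Nc1ncc(-c2ccc(OCc3ccccc3)c(Cl)c2)c(-c2ccccc2)n1` differs from compound 2 by benzyloxy in place of hydrogen on an aromatic carbon. Among the compounds with values here, no measured step bears on this change: the series so far has only exchanged one group for another on the same ring and never added a benzyloxy group. Within the data shown here, the only guide is that every variant of this ring has stayed at the limit. Compound 4 is expected to remain near that limit, at an estimated 82% (range 60% to 95%). The expected step that the limit leaves unreadable from compound 2 to compound 4 is estimated to lie within the scatter, with a fair chance that only a limit is reported again.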

Compound 4, a percentage reported as inhibition, at one concentration (the size of the read-out at that concentration, not a potency): 38%
Compound 4: middle estimate off by 44 percentage points, on the high side, and the stated range ends above it.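

In this assay, benzyloxy in place of hydrogen on the aromatic carbon ortho to the chloro group and para to a large group gives a number at least 42 percentage points lower from compound 2 to compound 4 (beyond the scatter). Within the data shown here, this is the only readable step, since the exchanges among methyl, chloro and methoxy cannot be read, and it shows that the read-out does not stay at the limit for every change on this ring. The step has a minimum size rather than an exact one, because compound 2 stands only at a limit: the limit of > 80% in this assay, at which 3 of the 4 values shown sit.

Going by these compounds, whether the drop follows from the benzene ring of the benzyloxy group or from its oxygen stays open, as does whether it would also occur without the chloro group. On these data alone, it is equally open whether a hydroxyl group, an ethoxy group or an amine on this carbon would keep the read-out at the limit.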